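This account rests on a few compounds, and the source may have more. Where it says the series, first, only, none or still open, it means among the compounds named here.

Measured in a functional assay on HCT-116 cells (Homo sapiens) for inhibition, with a stated time of 72 h; a lower number here means a stronger inhibitor, a higher number a weaker inhibitor:
- Compound 1 `COc1ccccc1-c1ccc(CNc2nc(NC3CCC(N)CC3)nc3c2ncn3C2CCCC2)cc1`: 430 nM
- Compound 2 `NC1CCC(Nc2nc(NCc3ccc(-c4cccc(F)c4)cc3)c3ncn(C4CCCC4)c3n2)CC1`: 551 nM
- Compound 3 `NC1CCC(Nc2nc(NCc3ccc(-c4ccsc4)cc3)c3ncn(C4CCCC4)c3n2)CC1`: 315 nM

These three compounds cannot be told apart on these numbers. Compound 3, at 315 nM, lies within the scatter of both others, so it cannot be ranked above them.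

The unmeasured compound 4 `NC1CCC(Nc2nc(NCc3ccc(-c4cccs4)nc3)c3ncn(C4CCCC4)c3n2)CC1` differs from compound 3 in one place: 6-(thiophen-2-yl)pyridin-3-yl stands in place of 4-(thiophen-3-yl)phenyl, on a saturated chain carbon bound to a nitrogen on an aromatic ring (6-(thiophen-2-yl)pyridin-3-yl in place of 4-(thiophen-3-yl)phenyl on a saturated chain carbon bound to a nitrogen on an aromatic ring).

Going by the values given here, three measured steps bear on this change, each exchanging one aromatic group for another: a 1.3-fold higher number from compound 1 to compound 2 (0.11 log units; within the scatter), a 1.4-fold lower number from compound 1 to compound 3 (0.14 log units; within the scatter) and a 1.7-fold lower number from compound 2 to compound 3 (0.24 log units; within the scatter). All three are small. However, none of them replaces a six-membered aromatic ring of carbon only with one containing a hetero atom, and none compares thiophen-3-yl with thiophen-2-yl. They therefore offer only indirect guidance, and the data contain no direct test of compound 4's new group.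

On this evidence, no step beyond the scatter is expected in this assay, although the uncertainty is wide. The expected change is a 1.3-fold higher number from compound 3 to compound 4 (0.10 log units; within the scatter). For compound 4 the estimated value is 400 nM, with an expected range from 150 nM to 1100 nM.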

Compound 4, half-maximal inhibitory concentration: 97 nM
Compound 4: middle estimate off by 4.1-fold (0.62 log units), on the high side; measured number outside the range, below it.
By their numbers in this assay, from the lowest: compound 4; then compounds 3, 1 and 2 (each within the scatter of the next).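

In this assay, going by these compounds alone, putting 6-(thiophen-2-yl)pyridin-3-yl in place of 4-(thiophen-3-yl)phenyl gives a 3.2-fold lower number from compound 3 to compound 4 (0.51 log units; beyond the scatter), the only step so far that lies beyond the scatter. The earlier exchanges of one outer aromatic group for another could not be told apart, whereas this change shows that the group on a saturated chain carbon bound to a nitrogen on an aromatic ring can shift the number measurably. The entering group differs in two ways at once, with a nitrogen in the six-membered aromatic ring, which adds one hydrogen-bond acceptor to the count, and thiophen-2-yl in place of thiophen-3-yl, and nothing available explains why the number falls.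

The compounds shown leave open which of these two differences carries the step, a question that 4-(thiophen-2-yl)phenyl and 6-(thiophen-3-yl)pyridin-3-yl would each help to separate. They also leave open whether the thiophene ring itself matters, which furan-2-yl or a plain phenyl ring on the same pyridine would test.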